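The compounds below may be only part of what the source reports. "The series", "measured", "known", "first", "only" and "open" are said of these compounds alone.

Working notes on the series. Compound 1 is `COc1cc(NC(=O)c2ccc(Cl)cc2)ccc1NS(=O)(=O)C(F)(F)F` and compound 2 is `CS(=O)(=O)Nc1ccc(NC(=O)c2ccc(Cl)cc2)cc1F`, both carrying the same chlorobenzamide and sulfonamide arrangement. In an ADME assay on HEK293 cells (Homo sapiens) for cytotoxicity, read by MTT assay, with a stated time of 48 h (a higher number here means a weaker inhibitor, a lower number a stronger inhibitor), compound 2 gives 216000 nM. Compound 1 reaches only a limit of the assay in this assay, > 250000 nM. Within the data shown here, compound 2 is therefore the single compound with a measured number in this assay; the other value sits at the limit of > 250000 nM in this assay, at which 1 of the 2 values shown sits. Compound 3 is `O=C(Nc1ccc(NS(=O)(=O)C(F)(F)F)c(F)c1)c1ccc(Cl)cc1` and has not yet been measured in this assay. The change from compound 2 is trifluoromethyl in place of methyl on a sulfonyl sulfur. Among the measured compounds shown here, no measured pair in the set isolates this change, so its size is not known from the data. The step from compound 2 to compound 3 is expected to be a 1.1-fold higher number from compound 2 to compound 3 (0.03 log units; within the scatter), not clearly beyond the scatter. Compound 3 is expected at 230000 nM, with a range of 100000 nM to 300000 nM, and a fair chance that only a limit is reported.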

Compound 3, half-maximal inhibitory concentration: 79000 nM
Compound 3: the middle estimate sits 2.9-fold (0.46 log units) above what was measured; the whole stated range lies above it.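

On the sulfonyl sulfur, trifluoromethyl in place of methyl now has a measured size in this assay: a 2.7-fold lower number from compound 2 to compound 3 (0.44 log units; beyond the scatter). With trifluoromethyl kept on the sulfonyl sulfur, fluoro in place of methoxy on an aromatic carbon also gives a step beyond the scatter, an at least 3.1-fold lower number from compound 1 to compound 3 (0.50 log units; beyond the scatter). That second step can be read only as a bound, because compound 1 stands at a limit of the assay: the limit of > 250000 nM in this assay, at which 1 of the 3 values shown sits.

The compounds shown leave open whether an ethyl chain or a phenyl ring on the sulfonyl sulfur would move the number in this assay as trifluoromethyl does. They also leave open whether the step from methoxy to fluoro would hold with methyl on the sulfonyl sulfur, and how an amine on that aromatic carbon would read.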